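Working notes: one group exchanged on compound 3

This account rests on a few compounds, and the source may have more. Where it says the series, first, only, none or still open, it means among the compounds named here.

- compound 1 `CC(O)(CSc1cccc(S(F)(F)(F)(F)F)c1)C(=O)Nc1ccc(C#N)c(C(F)(F)F)c1`: 31700 nM
- compound 2 `CC(O)(CSc1ccc(S(F)(F)(F)(F)F)cc1)C(=O)Nc1ccc([N+](=O)[O-])cc1C(F)(F)F`: 26300 nM
- compound 3 `CC(O)(COc1cccc(S(F)(F)(F)(F)F)c1)C(=O)Nc1ccc(S(F)(F)(F)(F)F)cc1`: 11400 nM

In a functional assay on VCaP cells (Homo sapiens) for antiproliferative activity, read by propidium iodide staining, with a stated time of 96 h (a higher number here means a weaker inhibitor, a lower number a stronger inhibitor), compound 3 gives 11400 nM as the lowest of the three numbers, with compound 1 and compound 2 both beyond the scatter from it. Compound 4 `CC(O)(COc1cccc(OC(F)(F)F)c1)C(=O)Nc1ccc(S(F)(F)(F)(F)F)cc1` differs from compound 3 at one place: a group of 5 heavy atoms (1 carbon, 1 oxygen, 3 fluorine; no ring) in place of a group of 6 heavy atoms (5 fluorine, 1 sulfur; no ring), on an aromatic carbon on an aromatic carbon, meta to a large group. Among the measured compounds shown here, no measured pair shows this exchange, so the expectation rests on the structural change alone. In this assay no step beyond the scatter is expected, with any drift toward a higher number. The estimated move is a 1.2-fold higher number from compound 3 to compound 4 (0.09 log units; within the scatter) (an expectation only). For compound 4 the expected value is 14000 nM (estimated range 6000 nM to 32000 nM).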

Compound 4, half-maximal inhibitory concentration: 18300 nM
Compound 4: middle estimate off by 1.3-fold (0.12 log units), on the low side; measured number inside the range.
By their numbers in this assay, from the lowest: compounds 3, 4, 2 and 1 (each within the scatter of the next, the first and the last beyond it).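

In this assay, trifluoromethoxy replacing the group of 6 heavy atoms (5 fluorine, 1 sulfur) on this aromatic carbon gives a 1.6-fold higher number from compound 3 to compound 4 (0.21 log units; within the scatter). Among the compounds shown here, this is the first pair that differs in one place, and it does not separate the two groups at this position. Nothing available explains the result or bears on it.

Going by these compounds, whether an amine or a carboxylic acid at this position would give a step beyond the scatter remains open. Also open, on these data alone, is whether the same exchange gives a similar step with a sulfur linker, as in compound 1.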